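Adding One Hydroxy Group to Compound 2

A few compounds are considered here, and "the series" means these few. Any claim that something is new, unique, unknown or untested is made for them only; others in the source may bear on it.

Three compounds set the scene: compound 1 `COc1ccc(C2=C(c3cc(OC)c(OC)c(OC)c3)C(=O)CC2C)cc1C(=O)O`, compound 2 `COc1ccc(C2=C(c3cc(OC)c(OC)c(OC)c3)C(=O)CC2O[SiH2]C(C)(C)C)cc1` and compound 3 `COc1cc(C2=C(c3ccc(OCC(=O)O)cc3)C(O)CC2=O)cc(OC)c1OC`. In an ADME assay on L132 cells (Homo sapiens) for cytotoxicity, read by MTT assay, with a stated time of 72 h (on this read-out lower numbers stand for stronger inhibition and higher numbers for weaker inhibition), compound 1 gives > 100 ug/mL, which is a limit of the assay and not a number. Compound 2 gives > 100 ug/mL, which is also a limit. For compound 3 the result reads "not determined" (no result reported). Compound 2 therefore stands at the limit of > 100 ug/mL in this assay, at which 2 of the 3 values shown sit, and it has no exact number to start from.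

Compound 4 `COc1ccc(C2=C(c3cc(OC)c(OC)c(OC)c3)C(=O)CC2O[SiH2]C(C)(C)C)cc1O` differs from compound 2 by a single change: hydroxy in place of hydrogen on an aromatic carbon. In words, 4-methoxyphenyl becomes 3-hydroxy-4-methoxyphenyl. Among the compounds with values here, no measured pair shows what this change does in this assay, so the expectation is loose: a modest move towards stronger inhibition, or nothing beyond the scatter. The expected size of the change is an at least 1.6-fold lower number from compound 2 to compound 4 (0.22 log units; that floor lies within the scatter). Compound 4 may well also be reported only as a limit. If a number is obtained, compound 4 is estimated at 60 ug/mL, with an expected range from 10 ug/mL to 200 ug/mL.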

Compound 4, half-maximal inhibitory concentration: < 1 ug/mL
Compound 4 was reported as a limit; the forecaster's own chance of this, stated with the estimate: 55%; middle value at least 60-fold (1.77 log units) from the limit.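

In this assay, hydroxy in place of hydrogen on an aromatic carbon, ortho to a methoxy group, gives an at least 100-fold lower number from compound 2 to compound 4 (2.00 log units; beyond the scatter), so this one-atom change at this position is enough to carry a compound from one end of the measured range to the other. Compound 4 stands at a limit of the assay, not at an exact number: the limit of < 1 ug/mL in this assay, at which 1 of the 4 values shown sits. Compound 2 stands at the opposite limit, so the step is only a floor and the true gap may be wider: the limit of > 100 ug/mL in this assay, at which 2 of the 4 values shown sit.

As far as these compounds go, with no exact number at either end, the full size of the step stays unknown. Also open, from the compounds shown here alone, is whether an amine or a fluorine at the same position would give a similar step, and whether the hydroxy group would have the same effect in a compound without the silyl ether shared by compound 2 and compound 4.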